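Fluoro on the terminal phenyl: working notes

The source may report more compounds than this note shows. Statements on the series, on what has been measured and on what is new or still open speak of the compounds shown alone.

Values in a functional assay on MDA-MB-231 cells (Homo sapiens) for antiproliferative activity, read by MTT assay, with a stated time of 72 h; a higher number here means a weaker inhibitor, a lower number a stronger inhibitor:
- compound 1 `CC(C)c1cccc(NC(=O)CCc2cccc3c2B(O)OC3)c1`: 1600 nM
- compound 2 `O=C(CCc1cccc2c1B(O)OC2)Nc1cccc(-c2ccccc2)c1`: 220 nM

Compound 2 holds the lower of the two measured numbers, at 220 nM. Compound 3 `O=C(CCc1cccc2c1B(O)OC2)Nc1cccc(-c2cccc(F)c2)c1` differs from it in one place: fluoro in place of hydrogen on an aromatic carbon. This is fluoro in place of hydrogen on an aromatic carbon, meta to a large group, so phenyl becomes 3-fluorophenyl.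

Going by the values given here, only one measured step bears on this change: a 7.3-fold lower number from compound 1 to compound 2 (0.86 log units; beyond the scatter). That step, phenyl in place of isopropyl, was modest and beyond the scatter, but it swapped a whole group. As far as these compounds go, no fluoro change has been measured, so the direction remains open. The expected change is a 1.1-fold lower number from compound 2 to compound 3 (0.04 log units; within the scatter), and no shift beyond the scatter is expected. For compound 3 the estimated value is 200 nM, with an expected range of 80 nM to 500 nM.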

Compound 3, half-maximal inhibitory concentration: 570 nM
The estimate for compound 3 lay 2.9-fold (0.45 log units) below the measured number, outside the stated range (above it).
By their numbers in this assay, from the lowest: compound 2; then compound 3; then compound 1.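

In this assay the terminal phenyl proves sensitive to a single added atom: fluoro in place of hydrogen gives a 2.6-fold higher number from compound 2 to compound 3 (0.41 log units; beyond the scatter) and so moves the number the wrong way at this place. Part of the earlier gain over isopropyl survives, with a 2.8-fold lower number from compound 1 to compound 3 (0.45 log units; beyond the scatter) still printed as beyond the scatter, so the 3-fluorophenyl compound keeps its lead over the isopropyl compound but falls short of the unsubstituted phenyl. No measurement at hand accounts for this loss.

As far as these compounds go, whether chloro, methoxy or an amine on the same aromatic carbon would follow fluoro remains open, so this single result cannot separate an effect of fluoro from an effect of any added group. Also open, from the compounds shown here alone, is whether a pyridine in place of the terminal phenyl would keep the number of compound 2 or lose ground.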